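Swapping fluoro for bromo on a rhodanine-type benzylidene

A few compounds are considered here, and "the series" means these few. Any claim that something is new, unique, unknown or untested is made for them only; others in the source may bear on it.

Three close relatives have been measured in a functional assay on HEp-2 cells (Homo sapiens) for cytotoxicity, read by MTT assay, with a stated time of 72 h, tested at 5 ug/mL; on this read-out higher numbers stand for more inhibition of growth at the one concentration tested and lower numbers for less inhibition of growth. Compound 1 `O=C1NC(=S)/C(=C/c2ccc(Br)cc2)S1` gives 15.4% in this assay. Compound 2 `O=C1NC(=S)/C(=C/c2cccc(F)c2)S1` gives 19.8%, and compound 3 `O=C1NC(=S)/C(=C/c2ccc(F)cc2)S1` gives 20.6%. All three numbers lie close together, and none of the gaps between them reaches beyond the usual scatter, so no one of them can be called the most or least growth-inhibiting.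

One structural change has already been tried once within this set. Going from compound 3 to compound 1 means (bromo in place of fluoro on an aromatic carbon), and this produced a number 5.2 percentage points lower from compound 3 to compound 1 (within the scatter). Compounds 2 and 3 share the same atoms joined differently; the difference between the two cores is not broken down here.

Compound 4 `O=C1NC(=S)/C(=C/c2cccc(Br)c2)S1` has not yet been measured. Going from compound 2 to compound 4 means (bromo in place of fluoro on an aromatic carbon). This is the same kind of change as from compound 3 to compound 1, not the same one, since the earlier bromo stands para to a group of 8 heavy atoms while here it stands meta to a group of 8 heavy atoms.

The step from compound 2 to compound 4 is expected to be a number 4.8 percentage points lower from compound 2 to compound 4 (within the scatter), resting on the earlier step of a number 5.2 percentage points lower from compound 3 to compound 1 (within the scatter), which stayed within the scatter. Compound 4 is therefore estimated at 15%, with a likely range from 5% to 26%.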

Compound 4, percent growth inhibition at one concentration: -1.04%
Compound 4: the middle estimate sits 16 percentage points above what was measured; measured number below the stated range.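

In this assay, putting bromo in place of fluoro on the core of compound 2 gave a number 20.8 percentage points lower from compound 2 to compound 4 (beyond the scatter). The same swap therefore did not carry over from one core to the other with the same size, so a step seen on one core was a poor guide to the step on the other: the same change on two cores in this assay, a number 5.2 percentage points lower (within the scatter) from compound 3 to compound 1 and a number 20.8 percentage points lower (beyond the scatter) from compound 2 to compound 4, 15.6 percentage points apart, beyond the scatter of two such steps

This shows only that, in this small series, the size of the step depends on which core carries the change; it rests on just two pairs of compounds, so it sets no rule for any further core. It also does not show why the two steps differ, since the numbers alone say nothing about the cause, and each step comes from a reading at a single concentration.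

The compounds shown carry only fluoro or bromo on the aromatic ring, so it remains open whether the large step belongs to bromo in this place or would also appear with another group. A chloro, a methoxy, an amine or a carboxylic acid at the same carbon could help to show how far the result on compound 4 extends.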